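A few compounds are considered here, and "the series" means these few. Any claim that something is new, unique, unknown or untested is made for them only; others in the source may bear on it.

Working notes on the series, all read in an ADME assay on J774 cells (Mus musculus) for antiproliferative activity, with a stated time of 72 h; on this read-out lower numbers stand for an effect already at smaller amounts and higher numbers for an effect only at larger amounts of compound. Compound 1 (`CCCCc1cc2c(=O)c(-c3cccnc3)c(C)[nH]c2cc1OCCOc1ccccc1`) gives 23000 nM, compound 2 (`CCCCc1cc2c(=O)c(-c3ccc(C(F)(F)F)cc3C)c(C)[nH]c2cc1OCCOc1ccccc1`) gives 20000 nM and compound 3 (`CCCCc1cc2c(=O)c(-c3ccc(C(F)(F)F)cc3F)c(C)[nH]c2cc1OCCOc1ccccc1`) gives 19000 nM. Compound 3 therefore stands level with the other two, and its steps to both lie within the scatter.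

The next structure is compound 4 (`CCCCc1cc2c(=O)c(-c3c(C)noc3C)c(C)[nH]c2cc1OCCOc1ccccc1`), with the change 3,5-dimethyl-1,2-oxazol-4-yl in place of 2-fluoro-4-(trifluoromethyl)phenyl on an aromatic carbon.

Two measured steps exchange the group on this same carbon: a 1.2-fold lower number from compound 1 to compound 2 (0.06 log units; within the scatter) and a 1.2-fold lower number from compound 1 to compound 3 (0.08 log units; within the scatter). The step of a 1.1-fold lower number from compound 2 to compound 3 (0.02 log units; within the scatter) alters only a substituent on that group. All three are within the scatter, though none of them tests a five-membered ring with two hetero atoms. On that evidence, no step beyond the scatter is expected in this assay, in either direction.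

The expected step is a 1.1-fold higher number from compound 3 to compound 4 (0.02 log units; within the scatter). For compound 4 the estimate is 20000 nM, with an expected range of 10000 nM to 40000 nM.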

Compound 4, half-maximal effective concentration: 22000 nM
Beside the measured number, compound 4's estimate is 1.1-fold (0.04 log units) below it; low and high end bracket the measured number.
By their numbers in this assay, from the lowest: compounds 3, 2, 4 and 1 (each within the scatter of the next).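

In this assay the five-membered 3,5-dimethyl-1,2-oxazol-4-yl ring, with 2 hetero atoms, now joins the groups read on this aromatic carbon, and the steps to it are a 1.2-fold higher number from compound 3 to compound 4 (0.06 log units; within the scatter) and a 1.1-fold higher number from compound 2 to compound 4 (0.04 log units; within the scatter) and also a 1.0-fold lower number from compound 1 to compound 4 (0.02 log units; within the scatter). At this position, then, a five-membered ring with 2 hydrogen-bond acceptors in place of a six-membered aromatic ring of carbon only goes with no step beyond the scatter, and all four compounds stand level. No measurement at hand offers an explanation for this flat picture.

Still open, going by these compounds, is whether any group on this carbon gives a step beyond the scatter, for instance a primary amine or a carboxylic acid. Also open, on these data alone, is whether the flat picture holds once the shared core itself is altered.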